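The source may hold more compounds than are shown below. What is called first, only, known or untested is meant among the compounds shown, and "the series" means these compounds.

Series notes, cytotoxicity on the shared core. Compound 1 `ClCc1cccc(Cn2cnc3c(Cl)ncnc32)c1` gives 6450 nM in a functional assay on MDA-MB-435 cells (Homo sapiens) for cytotoxicity, read by sulforhodamine B assay, with a stated time of 48 h; a lower number here means that less compound is tolerated, a higher number that more compound is tolerated; compound 2 `ClCc1ccccc1Cn1cnc2ncnc(Cl)c21` gives 7580 nM in this assay, the second highest of the three numbers, within the scatter of compound 1 and well apart from compound 3. For the measured compounds named here, compound 3 `Nc1nc(Cl)c2ncn(Cc3cccc(CCl)c3)c2n1` gives 85100 nM; the step of a 13-fold higher number from compound 1 to compound 3 (1.12 log units; beyond the scatter) is the only single-point change measured here. Compound 4 `ClCc1ccccc1Cn1cnc2nc(Cl)nc(Cl)c21` differs from compound 2 by chloro in place of hydrogen on an aromatic carbon. The step from compound 1 to compound 3 bears on it only loosely, since amino rather than chloro entered there, but it shows that adding a group at that site raised the number markedly. For compound 4 a smaller rise is therefore expected, a 1.5-fold higher number from compound 2 to compound 4 (0.16 log units; within the scatter), giving an estimated 11000 nM with a range of 4500 nM to 28000 nM.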

Compound 4, concentration lethal to 50% of the cells: 58900 nM
Estimate against measurement, compound 4: 5.4-fold (0.73 log units) below; the whole stated range lies below it.
By their numbers in this assay, from the lowest: compounds 1 and 2 (each within the scatter of the next); then compounds 4 and 3 (each within the scatter of the next).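

Chloro in place of hydrogen on the aromatic carbon between two ring nitrogen atoms gives a 7.8-fold higher number from compound 2 to compound 4 (0.89 log units; beyond the scatter) in this assay. For the compounds shown here, until now, the only change seen at this carbon was amino, with a 13-fold higher number from compound 1 to compound 3 (1.12 log units; beyond the scatter) on the same read-out. The rise in the number is therefore not tied to amino: a single chlorine atom also moves it beyond the scatter, on a core carrying the chloromethyl group at a different ring position.

Going by these compounds, whether methyl, methoxy or fluoro at this carbon would raise the number as well remains open. Nothing available here bears on why the number rises.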